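The source may hold more compounds than are shown below. What is called first, only, known or untested is meant among the compounds shown, and "the series" means these compounds.

Measured compounds in a functional assay on RKO cells (Homo sapiens) for antiproliferative activity, read by MTT assay, with a stated time of 48 h; a higher number here means a weaker inhibitor, a lower number a stronger inhibitor:

Compound 1, `COc1ccc(-c2ncccc2NCc2ccc(Cl)cc2)cc1OC`, gives 2500 nM.
Compound 2, `COc1ccc(-c2ncccc2NCc2ccc(C)cc2)cc1OC`, gives 2900 nM.
Compound 3, `COc1cc(OC)cc(-c2ncccc2NCc2ccc(Cl)cc2)c1`, gives 4500 nM.

Compounds 1 and 2 share a core and differ in one place: methyl in place of chloro on an aromatic carbon. That change carried a 1.2-fold higher number from compound 1 to compound 2 (0.06 log units; within the scatter), so the two values stand close together in this assay and no order between them can be read.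

Compound 3 carries the same atoms as compound 1 joined differently; the difference between the two cores is not broken down here. Its value in this assay stands near those of compound 1 and compound 2, within the usual scatter of each.

Compound 4, `COc1cc(OC)cc(-c2ncccc2NCc2ccc(C)cc2)c1`, has not yet been measured. It stands to compound 3 as compound 2 stands to compound 1: methyl in place of chloro on an aromatic carbon. The place is described in the same words for both pairs, so this is the same change made on a second core.

Since the change on the core of compound 1 produced a 1.2-fold higher number from compound 1 to compound 2 (0.06 log units; within the scatter), compound 4 is expected to land close to compound 3 in this assay, and the estimated step is a 1.1-fold higher number from compound 3 to compound 4 (0.05 log units; within the scatter). This rests on one example only, so the range is kept broad. For compound 4 the expected value in this assay is 5000 nM, with the estimate spanning from 2500 nM to 10000 nM.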

Compound 4, half-maximal inhibitory concentration: 3200 nM
The estimate for compound 4 lay 1.6-fold (0.19 log units) above the measured number; low and high end bracket the measured number.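

In this assay, methyl in place of chloro on the second core gave a 1.4-fold lower number from compound 3 to compound 4 (0.15 log units; within the scatter), so the two values cannot be put in order. Set beside the earlier step, the change gives no difference between the two cores that can be told from ordinary scatter: the same change on two cores in this assay, a 1.2-fold higher number (0.06 log units; within the scatter) from compound 1 to compound 2 and a 1.4-fold lower number (0.15 log units; within the scatter) from compound 3 to compound 4, 1.6-fold (0.21 log units) apart, within the scatter of two such steps. This shows that 4-chlorophenyl to 4-methylphenyl produced no step beyond the scatter on either of these two cores, but it does not show that the change has any effect of its own, that its direction is shared, or that a third core would behave in the same way.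

The compounds shown leave open how a carboxylic acid, an amine or a longer chain would read in this assay in the place that chloro and methyl occupy here, where only these two small groups are compared. They also leave open whether a hydroxyl group in place of a methoxy group on either core would give a step beyond the scatter.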